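Pyridine in Place of Phenyl on the Amide of Compound 2

This account rests on a few compounds, and the source may have more. Where it says the series, first, only, none or still open, it means among the compounds named here.

Measured so far, with the read-out of an assay on CHO cells, read by calcium flux; a lower number here means a stronger inhibitor, a higher number a weaker inhibitor:
- Compound 1, `O=C(Nc1ccccc1)c1csc(Cc2c(Cl)cccc2Cl)n1`: in this assay compound 1 gives > 4000 nM, which is a limit of the assay and not a number.
- Compound 2, `O=C(Nc1ccc(Br)cc1)c1csc(Cc2c(Cl)cccc2Cl)n1`: compound 2 gives 460 nM.
- Compound 3, `O=C(Nc1ccc(C(F)(F)F)cc1)c1csc(Cc2c(Cl)cccc2Cl)n1`: compound 3 gives 88 nM.

The three compounds share one core and differ only in the group carried on the ring attached to the amide nitrogen. Compound 1 sits at the limit (the limit of > 4000 nM in this assay, at which 1 of the 3 values shown sits). From there the measured steps are an at least 8.6-fold lower number from compound 1 to compound 2 (0.93 log units; beyond the scatter) and an at least 45-fold lower number from compound 1 to compound 3 (1.65 log units; beyond the scatter), and between the two numbered compounds a 5.2-fold lower number from compound 2 to compound 3 (0.72 log units; beyond the scatter). Among the measured compounds shown here, compound 2 therefore stands highest of the two numbers, with compound 3 as its only numbered neighbour.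

Compound 4, `O=C(Nc1ccc(Br)cn1)c1csc(Cc2c(Cl)cccc2Cl)n1`, differs from compound 2 by 5-bromopyridin-2-yl in place of 4-bromophenyl on an amide-type nitrogen. None of the three measured steps tests this kind of change: each of them swaps the group on one aromatic carbon, whereas here the bromo is kept and only the ring that carries it changes. For the measured compounds named here, with no step of this kind to lean on, the expectation is a 1.2-fold higher number from compound 2 to compound 4 (0.08 log units; within the scatter), a step not clearly beyond the scatter. Compound 4 is thus estimated at 550 nM, with a range from 150 nM to 2500 nM.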

Compound 4, half-maximal inhibitory concentration: > 4000 nM
Compound 4: only a limit was reported; the forecaster's own chance of this, stated with the estimate: 15%; middle value at least 7.2-fold (0.86 log units) from the limit.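

Every earlier step at this end of the molecule kept the ring and swapped the group on one of its aromatic carbons, whereas compound 4 keeps the bromo and replaces the ring that carries it, turning 4-bromophenyl into 5-bromopyridin-2-yl on the amide-type nitrogen, and in this assay this gives an at least 8.6-fold higher number from compound 2 to compound 4 (0.93 log units; beyond the scatter). The bromo alone therefore does not secure the reading of compound 2: with the same group and the same shared core, the change to a ring holding one nitrogen and one hydrogen-bond acceptor is enough to lose it, so at this position the ring matters as well as the group it carries. Compound 4, like compound 1, rests at a limit of the assay and not at a number, so the step between these two cannot be read: the limit of > 4000 nM in this assay, at which 2 of the 4 values shown sit.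

Going by these compounds, how far compound 4 actually lies beyond that limit stays open. Also open, on these data alone, is whether the 5-bromopyridin-2-yl result holds for this ring in general, or would change if the bromo gave way to trifluoromethyl, a nitrile or an amine.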